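Chloro in place of aryl hydrogen on compound 1

This account rests on a few compounds, and the source may have more. Where it says the series, first, only, none or still open, it means among the compounds named here.

Compound 1 `CC(C(=O)N1CCN(c2ccccc2)CC1)N1C(=O)CCC1=O` stands highest of the two numbers recorded so far; in a functional assay on the whole organism (strain Swiss) with Mus musculus as the target, in the maximal electroshock model, with a stated time of 0.25 h, at a dose of 300 mg/kg by the intraperitoneal route (a lower number here means a weaker effect, a higher number a stronger effect of the compound at the dose given), compound 1 gives 100%. Going by the values given here, the only other measured member, compound 2 `CCC(C(=O)N1CCN(c2ccccc2C(F)(F)F)CC1)N1C(=O)CCC1=O`, differs from it in more than one place, and in this assay compound 2 gives 25%, a gap beyond the scatter. Compound 3 `CC(C(=O)N1CCN(c2ccccc2Cl)CC1)N1C(=O)CCC1=O` carries the change chloro in place of hydrogen on an aromatic carbon relative to compound 1. Among the compounds with values here, no step between measured compounds isolates this change. The expected step of a number 25 percentage points lower from compound 1 to compound 3 (beyond the scatter) is therefore a modest drop, possibly none beyond the scatter, because compound 1 already sits at 100%. Compound 3 is expected to give 75% in this assay, within 30% to 100%.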

Compound 3, a percentage reported as activity, at one dose (the size of the read-out at that dose, not a potency): 0%
The estimate for compound 3 lay 75 percentage points above the measured number, and the stated range ends above it.
By their numbers in this assay, from the lowest: compound 3; then compound 2; then compound 1.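

Going by these compounds alone, the change from phenyl to 2-chlorophenyl gives the only single-place step so far: in this assay there is a number 100 percentage points lower from compound 1 to compound 3 (beyond the scatter), a large step. The earlier compounds shown here could not isolate this position, and it now appears that on this aromatic carbon, ortho to a large group, one chloro in place of hydrogen removes the read-out at the dose given. Nothing available bears on the origin of this loss.

Going by these compounds, it remains open whether fluoro or methoxy at this position would keep the read-out. Also open, on these data alone, is how chloro would behave on another carbon of the ring.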